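Enlarging the Piperazine Substituent of Compound 1

A few compounds are considered here, and "the series" means these few. Any claim that something is new, unique, unknown or untested is made for them only; others in the source may bear on it.

Three compounds have been measured in an assay on isolated protein for binding affinity to 5-hydroxytryptamine receptor 1D (Homo sapiens); on this read-out higher numbers stand for weaker inhibition and lower numbers for stronger inhibition:

compound 1, `COc1cc2c(cc1N1CCN(C)CC1)N(C(=O)c1ccc(-c3cccc(C)n3)c3ccccc13)CC2`, gives 25.1 nM
compound 2, `COc1cc2c(cc1N1C[C@@H](C)N(C)[C@@H](C)C1)N(C(=O)Nc1cccc(Cl)c1Cl)CC2`, gives 79.4 nM
compound 3, `COc1cc2c(cc1N1C[C@@H](C)N[C@@H](C)C1)N(C(=O)c1ccc(-c3ccc(-c4ncccn4)cc3C)cc1)CC2`, gives 251 nM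

Among these, compound 1 gives the lowest number in this assay, that is the strongest binding. Compound 2 comes nearest, with a number beyond the scatter, and compound 3 lies furthest away, also beyond the scatter. Since compound 2 and compound 3 each differ from compound 1 in more than one place, their values show only that both bind more weakly, not which of their changes is responsible.

Compound 4, `CCN1[C@H](C)CN(c2cc3c(cc2OC)CCN3C(=O)c2ccc(-c3cccc(C)n3)c3ccccc23)C[C@@H]1C`, has not yet been measured. It keeps the core and the amide part of compound 1 and differs only in the substituent on the aromatic carbon: 4-ethyl-3,5-dimethylpiperazin-1-yl in place of 4-methylpiperazin-1-yl on an aromatic carbon. The ring system stays the same, the count of hydrogen-bond acceptors stays the same, and only carbon atoms are added.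

Among the measured compounds shown here, no measured pair shows this change on its own, so the expectation rests on the change being small. The step from compound 1 to compound 4 in this assay is estimated at a 1.6-fold higher number from compound 1 to compound 4 (0.20 log units; within the scatter), a small shift toward a higher number, close to the scatter. Compound 4 is expected to give about 40 nM, within a range from 12 nM to 130 nM.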

Compound 4, inhibition constant: 126 nM
For compound 4 the middle estimate is 3.2-fold (0.50 log units) below the measured one, and the stated range covers the measured number.
By their numbers in this assay, from the lowest: compound 1; then compounds 2, 4 and 3 (each within the scatter of the next, the first and the last beyond it).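

In this assay, putting 4-ethyl-3,5-dimethylpiperazin-1-yl in place of 4-methylpiperazin-1-yl gives a 5.0-fold higher number from compound 1 to compound 4 (0.70 log units; beyond the scatter), a modest step but one beyond the scatter, so this position on the aromatic carbon, ortho to a methoxy group, does respond to what the piperazine ring carries. Compounds 2 and 3 could not show this, as each differs from compound 1 in more than one place, whereas compound 4 keeps the core and the amide part of compound 1 and changes only this substituent, adding carbon atoms and two defined stereocentres while the ring type and the counts of hydrogen-bond donors and acceptors stay the same. No measurement available here accounts for the weaker binding.

Among the compounds shown here, the ethyl group and the two ring methyl groups entered together, so their shares of the step remain unseparated; 4-ethylpiperazin-1-yl and 3,4,5-trimethylpiperazin-1-yl on the core of compound 1 would each carry only one part of the change. Also open, going by these compounds, is how this position responds to a piperazine with a hydrogen on the outer ring nitrogen, or to a morpholine ring.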